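The compounds below may be only part of what the source reports. "The series", "measured", "known", "first", "only" and "open" are said of these compounds alone.

For the measured compounds named here, in an assay on isolated protein for inhibition of cytosolic endo-beta-N-acetylglucosaminidase (Homo sapiens), tested at 1000 uM (on this read-out lower numbers stand for less inhibition and higher numbers for more inhibition at the one concentration tested (going by the name of the read-out)), compound 3 `O=C(O)[C@@H]1NC[C@@H](O)[C@H](O)[C@H]1O` gives 50%, the highest of the three numbers measured so far. Compound 1 `O=C(O)[C@H]1NC[C@@H](O)[C@@H](O)[C@@H]1O` gives 28% and compound 2 `O=C(O)[C@@H]1NC[C@@H](O)[C@@H](O)[C@@H]1O` gives 2.1%. All three share one set of atoms and bonds, and their numbers differ because of configuration alone the fact that compounds 1 and 2 differ only in the configuration as drawn the fact that compounds 1 and 3 differ only in the configuration as drawn (the fact that compounds 2 and 3 differ only in the configuration as drawn). Going by the values given here, compound 4 `O=C(O)[C@@H]1NC[C@@H](O)[C@H](O)[C@@H]1O` is a further stereoisomer, and its difference from compound 3 is counted here: the two compounds have the same atoms and bonds and differ only in configuration as drawn: 1 of 4 stereo elements differ; a stereocentre at a saturated ring carbon is drawn S in compound 3 and R in compound 4 The step that bears most directly on this change is the single inversion a number 25.9 percentage points lower from compound 1 to compound 2 (beyond the scatter), which was modest and downward; the larger changes a number 22 percentage points higher from compound 1 to compound 3 (beyond the scatter) and a number 47.9 percentage points higher from compound 2 to compound 3 (beyond the scatter) involved several centres at once. Since compound 3 already stands at the top, a single inversion in compound 4 is expected to lower the number modestly, giving an expected step of a number 25 percentage points lower from compound 3 to compound 4 (beyond the scatter). Compound 4 is therefore estimated at 25%, within a range from 5% to 50%.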

Compound 4, a percentage reported as inhibition, at one concentration (the size of the read-out at that concentration, not a potency): 0.8%
Compound 4: the middle estimate sits 24.2 percentage points above what was measured; the measured number lies below the stated range.
By their numbers in this assay, from the lowest: compounds 4 and 2 (each within the scatter of the next); then compound 1; then compound 3.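

In this assay, inverting one stereocentre takes away nearly all the inhibition of compound 3: a number 49.2 percentage points lower from compound 3 to compound 4 (beyond the scatter) is a large step, whereas the earlier single inversion, a number 25.9 percentage points lower from compound 1 to compound 2 (beyond the scatter), was modest. For the compounds shown here, the effect of an inversion depends on the stereoisomer and centre concerned, since the single inversion in a number 1.3 percentage points lower from compound 2 to compound 4 (within the scatter) leaves those two compounds unseparated, while the two inversions in a number 27.2 percentage points lower from compound 1 to compound 4 (beyond the scatter) give a modest step. Nothing but configuration can account for the large step, as the atoms and bonds stay the same, which rests on: the fact that compounds 3 and 4 differ only in the configuration as drawn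

From the compounds shown here alone, all four compounds were read at one concentration, so how their potencies compare remains open. Going by these compounds, all four also carry the carboxylic acid, so whether an amide or a hydroxymethyl group in its place would preserve the inhibition of compound 3 is unknown.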